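Amine-to-amide swap on the macrocyclic enone series

A few compounds are considered here, and "the series" means these few. Any claim that something is new, unique, unknown or untested is made for them only; others in the source may bear on it.

Measured so far:
compound 1 `CC(=O)O[C@]1(C)/C=C/C(=O)/C(CO)=C\C[C@](C)(CCC=C(C)C)/C=C/[C@H]1OC(=O)C=C(C)C`: 2320 nM
compound 2 `CO[C@]1(C)/C=C/C(=O)/C(CO)=C\C[C@](C)(CCC=C(C)C)/C=C/[C@H]1OC(=O)C=C(C)C`: 14300 nM
compound 3 `CCN(CC)C/C1=C/C[C@](C)(CCC=C(C)C)/C=C/[C@@H](OC(=O)C=C(C)C)[C@](C)(O)/C=C/C1=O`: 130 nM

In a functional assay on MCF7 cells (Homo sapiens) for antiproliferative activity, read by MTT assay, with a stated time of 48 h (a higher number here means a weaker inhibitor, a lower number a stronger inhibitor), compound 3 gives 130 nM and stands lowest of the three numbers; compound 1 is nearest, compound 2 furthest. Compound 4 `CC(C)=CCC[C@]1(C)/C=C/[C@@H](OC(=O)C=C(C)C)[C@](C)(O)/C=C/C(=O)/C(C(=O)N2CCCC2)=C\C1` is not yet measured. Its difference from compound 3: (pyrrolidin-1-yl)carbonyl in place of (diethylamino)methyl on a double-bonded ring carbon. Among the compounds with values here, the only measured step, a 6.2-fold higher number from compound 1 to compound 2 (0.79 log units; beyond the scatter), concerns an ester-to-ether change on a saturated carbon and does not touch the ring carbon changed here, so no measured step bears on this change. Given the replacement of a basic amine by an amide, compound 4 is expected to give a higher number than compound 3, with the step of a 4.6-fold higher number from compound 3 to compound 4 (0.66 log units; beyond the scatter) estimated, though the range is wide. Compound 4 is estimated at 600 nM, between 150 nM and 3000 nM.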

Compound 4, half-maximal inhibitory concentration: 17200 nM
The estimate for compound 4 lay 29-fold (1.46 log units) below the measured number, and the stated range ends below it.
By their numbers in this assay, from the lowest: compound 3; then compound 1; then compounds 2 and 4 (each within the scatter of the next).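

In this assay, the change to (pyrrolidin-1-yl)carbonyl in place of (diethylamino)methyl gives a 130-fold higher number from compound 3 to compound 4 (2.12 log units; beyond the scatter) and shows that the number depends strongly on the group at this double-bonded ring carbon. Within the data shown here, the earlier step concerned only an oxygen on a saturated carbon, so this is the first reading at this ring carbon. Nothing measured on these compounds accounts for the size of the step.

From the compounds shown here alone, the carbonyl and the pyrrolidine ring enter together, so their separate contributions remain open. A pyrrolidin-1-ylmethyl group or a diethylaminocarbonyl group on this carbon would separate them.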